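Methoxy on the Indole Ring and Breast Cancer Cell Growth

The source may hold more compounds than are shown below. What is called first, only, known or untested is meant among the compounds shown, and "the series" means these compounds.

The three measured compounds share an isoxazoline linking an indole to a second aromatic ring, and all were tested in a functional assay on MDA-MB-231 cells (Homo sapiens) for inhibition, read by MTT assay, with a stated time of 48 h; on this read-out higher numbers stand for weaker inhibition and lower numbers for stronger inhibition. Compound 1, `COc1cc(C2=NOC(c3c[nH]c4ccccc34)C2)cc(OC)c1OC`, carries a trimethoxyphenyl on the isoxazoline and an unsubstituted indole; in this assay compound 1 gives 11700 nM. Compound 2, `COc1ccc2c(C3CC(c4ccncc4)=NO3)c[nH]c2c1`, bears a pyridyl instead and a methoxy on the indole, and in this assay compound 2 gives 7380 nM. Compound 3, `c1ccc2c(C3CC(c4ccncc4)=NO3)c[nH]c2c1`, is compound 2 without that methoxy; in this assay compound 3 gives 19700 nM. The values of compound 1 and compound 2, and of compound 1 and compound 3, lie within the usual scatter of each other, so no order among them is claimed. The difference between the cores of compound 1 and compound 3 is not broken down here.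

One single-point change is measured: methoxy in place of hydrogen on an aromatic carbon This change produced a 2.7-fold lower number from compound 3 to compound 2 (0.43 log units; beyond the scatter).

Compound 4, `COc1ccc2[nH]cc(C3CC(c4cc(OC)c(OC)c(OC)c4)=NO3)c2c1`, arises from compound 1 by the same change: methoxy in place of hydrogen on an aromatic carbon Since the place is the same in both pairs, the same kind of change is made. Going by the values given here, a step similar to the one from compound 3 to compound 2 is expected, so that from compound 1 to compound 4 the estimate means a 2.3-fold lower number from compound 1 to compound 4 (0.37 log units; beyond the scatter). Because a single precedent, a 2.7-fold lower number from compound 3 to compound 2 (0.43 log units; beyond the scatter), underlies it, the expectation is held with caution. Compound 4 is therefore estimated to give 5000 nM in this assay, expected to fall between 2000 nM and 12000 nM.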

Compound 4, half-maximal inhibitory concentration: 26000 nM
Beside the measured number, compound 4's estimate is 5.2-fold (0.72 log units) below it; measured number above the stated range.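

In this assay, the methoxy step ran the opposite way on the second core, with a 2.2-fold higher number from compound 1 to compound 4 (0.35 log units; beyond the scatter). Set beside the earlier step, the same change did not carry over from one core to the other, in direction or in size: the same change on two cores in this assay, a 2.7-fold lower number (0.43 log units; beyond the scatter) from compound 3 to compound 2 and a 2.2-fold higher number (0.35 log units; beyond the scatter) from compound 1 to compound 4, 5.9-fold (0.77 log units) apart, beyond the scatter of two such steps This shows that, in these two pairs, the outcome of placing a methoxy on the indole depends on the rest of the molecule, so the step seen on one core could not be transferred to the other; it does not show which part of the rest is responsible, as the pyridyl and the trimethoxyphenyl are the only two partners shown, and two pairs give no rule for any further core.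

The compounds shown leave open whether another group on the same aromatic carbon, such as a hydroxyl, a fluorine or an amine, would follow the step seen on one core, the step seen on the other, or neither. They also leave open how the methoxy step would turn out with a plain phenyl in the place of the pyridyl or the trimethoxyphenyl, which could help show what separates the two cores.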